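Swapping 4-methylphenyl for 3-chlorophenyl on the shared core

The source may report more compounds than this note shows. Statements on the series, on what has been measured and on what is new or still open speak of the compounds shown alone.

In an ADME assay on Vero 76 cells (Chlorocebus sabaeus) for cytotoxicity, read by MTT assay, with a stated time of 96 h (on this read-out higher numbers stand for lower toxicity in this test and lower numbers for higher toxicity in this test), compound 3 (`Cc1ccc(C2CC(c3ccc(Oc4ccccc4)cc3)=NN2c2ccc(S(N)(=O)=O)cc2)cc1`) gives 86000 nM. Among the measured compounds shown here, that is the second highest of three numbers so far. It lies within the scatter of compound 1 (`Cc1ccc(C2CC(c3ccc(OCc4ccccc4)cc3)=NN2c2ccc(S(N)(=O)=O)cc2)cc1`) at 100000 nM, and compound 2 (`NS(=O)(=O)c1ccc(N2N=C(c3ccc(Oc4ccccc4)cc3)CC2c2cccc(F)c2)cc1`) sits clearly lower at 28000 nM.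

Compound 4 (`NS(=O)(=O)c1ccc(N2N=C(c3ccc(Oc4ccccc4)cc3)CC2c2cccc(Cl)c2)cc1`) has 3-chlorophenyl in place of 4-methylphenyl on a saturated ring carbon, next to the ring nitrogen (3-chlorophenyl in place of 4-methylphenyl on a saturated ring carbon).

The step that bears most on this change is a 3.1-fold higher number from compound 2 to compound 3 (0.49 log units; beyond the scatter), a modest one, where 4-methylphenyl replaces 3-fluorophenyl on that same carbon. The other step, a 1.2-fold lower number from compound 1 to compound 3 (0.07 log units; within the scatter), concerns phenyl in place of benzyl on an oxygen, elsewhere in the structure, and says little here. For the measured compounds named here, no measured compound carries 3-chlorophenyl, so compound 2 at 28000 nM is only the nearest guide.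

A modest move towards a lower number is therefore expected, and the estimated step is a 2.5-fold lower number from compound 3 to compound 4 (0.39 log units; beyond the scatter). For compound 4 the expected value in this assay is 35000 nM, with an estimated range from 15000 nM to 80000 nM.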

Compound 4, half-maximal cytotoxic concentration: 88000 nM
Compound 4: middle estimate off by 2.5-fold (0.40 log units), on the low side; the measured number lies above the stated range.
By their numbers in this assay, from the lowest: compound 2; then compounds 3, 4 and 1 (each within the scatter of the next).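

In this assay, 3-chlorophenyl in place of 4-methylphenyl on this saturated ring carbon gives a 1.0-fold higher number from compound 3 to compound 4 (0.01 log units; within the scatter) and so leaves the read-out unchanged within the scatter. Chloro in place of fluoro on an aromatic carbon gives a 3.1-fold higher number from compound 2 to compound 4 (0.50 log units; beyond the scatter) and thus shows that a change of one atom on this ring can matter more here than a change of both the substituent and its place on the ring. No measurement at hand accounts for this difference between fluoro and chloro.

From the compounds shown here alone, whether 4-fluorophenyl on this carbon would read like 3-fluorophenyl or like 4-methylphenyl remains open. Going by these compounds, how an amine or a carboxylic acid on this ring would read is also open.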